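Ester chain length in the shared-core series

The source may report more compounds than this note shows. Statements on the series, on what has been measured and on what is new or still open speak of the compounds shown alone.

Measured so far:
Compound 1, `CCCC(C)ON1C(=O)c2ccccc2C1=O`, gives 0% in a functional assay on the whole organism for inhibition, with Lepidium sativum as the target, tested at 1 ppm; a higher number here means more inhibition of growth at the concentration tested, a lower number less inhibition of growth.
Compound 2, `CCCOC(=O)C(C)ON1C(=O)c2ccccc2C1=O`, gives 64% in this assay.
Compound 3, `CCOC(=O)C(C)ON1C(=O)c2ccccc2C1=O`, gives 68% in this assay.

Compound 3 stands at the upper end of the three numbers, but its gap to compound 2 is within the scatter, as a number 4 percentage points higher from compound 2 to compound 3 (within the scatter) shows; only compound 1 sits well apart, with a number 68 percentage points higher from compound 1 to compound 3 (beyond the scatter).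

Compound 4, `CCC(C)OC(=O)C(C)ON1C(=O)c2ccccc2C1=O`, differs from compound 3 by ethyl in place of hydrogen on a saturated chain carbon bound to an oxygen next to a carbonyl group and a saturated chain carbon. Within the data shown here, the one measured step of the same kind, an alkyl change on the ester side, is a number 4 percentage points higher from compound 2 to compound 3 (within the scatter), which is within the scatter. The two large steps, a number 64 percentage points higher from compound 1 to compound 2 (beyond the scatter) and a number 68 percentage points higher from compound 1 to compound 3 (beyond the scatter), concern the ester versus the plain propyl chain and do not touch the ester alkyl, so they do not bear on this change. Nothing in the series points to a shift beyond the scatter in this assay for lengthening the ester alkyl.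

The expected step is therefore a number 3 percentage points lower from compound 3 to compound 4 (within the scatter), in no direction beyond the scatter. Compound 4 is estimated at 65%, with a range from 48% to 80%.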

Compound 4, percent growth inhibition at one concentration: 42%
Beside the measured number, compound 4's estimate is 23 percentage points above it; the measured number lies below the stated range.
By their numbers in this assay, from the lowest: compound 1; then compound 4; then compounds 2 and 3 (each within the scatter of the next).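

The ester alkyl is not a silent position in this assay: ethyl in place of hydrogen on the saturated chain carbon bound to an oxygen next to a carbonyl group gives a number 26 percentage points lower from compound 3 to compound 4 (beyond the scatter) and methyl in place of hydrogen on that same carbon gives a number 22 percentage points lower from compound 2 to compound 4 (beyond the scatter), whereas the earlier change two bonds along the chain from that oxygen, a number 4 percentage points higher from compound 2 to compound 3 (within the scatter), stayed within the scatter. Among these compounds, then, the carbon bound to the ester oxygen responds to added alkyl, and the sec-butoxycarbonyl group still leaves a number 42 percentage points higher from compound 1 to compound 4 (beyond the scatter), so the gain over the plain propyl chain survives this change in reduced form. No measurement is at hand that explains the loss at this carbon.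

Open, as far as these compounds go, is how an isopropoxycarbonyl group, with methyl in place of hydrogen on the ethoxycarbonyl carbon, or a tert-butoxycarbonyl group would read in this assay, and so whether the loss tracks the size of the added alkyl. Also open, from the compounds shown here alone, are a longer chain such as hexyl on the ester oxygen and a carboxylic acid in place of the ester.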